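Ethylamino for dimethylamino on the carbonyl: cytotoxicity notes

The source may hold more compounds than are shown below. What is called first, only, known or untested is meant among the compounds shown, and "the series" means these compounds.

The series shares one core and varies only the group on a carbonyl carbon. In an ADME assay on J774 cells (Mus musculus) for cytotoxicity (on this read-out higher numbers stand for an effect only at larger amounts of compound and lower numbers for an effect already at smaller amounts), compound 1 `CCCCc1cc2c(=O)c(C(C)=O)c[nH]c2cc1OCCOc1ccccc1` has "not determined" (no result reported). Compound 2 `CCCCc1cc2c(=O)c(C(=O)OC)c[nH]c2cc1OCCOc1ccccc1` gives > 20000 nM, and this is a limit of the assay, not a number. Within the data shown here, compound 3 `CCCCc1cc2c(=O)c(C(=O)N(C)C)c[nH]c2cc1OCCOc1ccccc1` gives 15300 nM, the only true number in the set so far, so it can be ranked against no other measured value.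

Compound 4 `CCCCc1cc2c(=O)c(C(=O)NCC)c[nH]c2cc1OCCOc1ccccc1` is the next to be read in this assay. The change is ethylamino in place of dimethylamino on a carbonyl carbon, with the same atoms joined differently: ethylamino in place of dimethylamino on a carbonyl carbon.

Among the measured compounds shown here, only one measured step bears on this, and it sits on the same carbonyl carbon: an at least 1.3-fold lower number from compound 2 to compound 3 (0.11 log units; that floor lies within the scatter). That step rests on a limit, and it does not show how far a change here can move the read-out. It replaces a different group from the one now in question, so it gives no direction for the new change. No step beyond the scatter is therefore expected, and the estimated change is a 1.0-fold lower number from compound 3 to compound 4 (0.01 log units; within the scatter). A result reported only as a limit would not be surprising. For compound 4 the expected value is 15000 nM, with an estimated range from 8000 nM to 20000 nM.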

Compound 4, half-maximal effective concentration: > 20000 nM
Compound 4 ended at the assay's limit (the forecaster's own chance of this, stated with the estimate: 30%); middle value at least 1.3-fold (0.12 log units) from the limit.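

In this assay, ethylamino in place of dimethylamino on the carbonyl carbon gives an at least 1.3-fold higher number from compound 3 to compound 4 (0.11 log units; that floor lies within the scatter) and so compares two groups with the same atoms joined differently, the entering one carrying a hydrogen-bond donor, though the floor of that step does not clear the scatter. Compound 4 gives > 20000 nM as a limit of the assay, not a number. The step between methoxy and ethylamino on this carbon cannot be read, and compound 3 remains the only compound with a true number, so the spread at this position is still bounded on one side only: the limit of > 20000 nM in this assay, at which 2 of the 4 values shown sit.

From the compounds shown here alone, it remains open whether any group on this carbonyl carbon moves the read-out beyond the scatter, and compound 1 stands at "not determined" (no result reported) and adds nothing to that question. The compounds shown include no carboxylic acid at this carbon and no longer amine such as butylamino or morpholine, so the place of those groups relative to compound 3 is unknown.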